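The source may hold more compounds than are shown below. What is called first, only, known or untested is meant among the compounds shown, and "the series" means these compounds.

Compound 1 `COc1cccc(N(C)S(=O)(=O)C2CC3OC2C(c2ccc(NC(=O)CCCCCCC(=O)O)cc2)=C3c2ccc(O)cc2)c1` gives 62200 nM
Compound 2 `CN(c1cccc2ccccc12)S(=O)(=O)C1CC2OC1C(c1ccc(NC(=O)CCCCCCC(=O)O)cc1)=C2c1ccc(O)cc1` gives 70900 nM
Compound 3 `CCN(c1cccc(OC)c1)S(=O)(=O)C1CC2OC1C(c1ccc(NC(=O)CCCCCCC(=O)O)cc1)=C2c1ccc(O)cc1` gives 71100 nM

In a functional assay on DU-145 cells (Homo sapiens) for antiproliferative activity, read by MTT assay, with a stated time of 72 h (a lower number here means a stronger inhibitor, a higher number a weaker inhibitor), compound 3 stands at (71100 nM) within the scatter of both other measured compounds. Compound 4 `CCN(c1ccccc1Cl)S(=O)(=O)C1CC2OC1C(c1ccc(NC(=O)CCCCCCC(=O)O)cc1)=C2c1ccc(O)cc1` carries 2-chlorophenyl in place of 3-methoxyphenyl on a sulfonamide nitrogen. The closest measured change on that nitrogen is the exchange of its ring group (a 1.1-fold higher number from compound 1 to compound 2 (0.06 log units; within the scatter)). The remaining steps are as small (a 1.0-fold higher number from compound 2 to compound 3 (0.00 log units; within the scatter)) and (a 1.1-fold higher number from compound 1 to compound 3 (0.06 log units; within the scatter)). Going by the values given here, no 2-chlorophenyl compound has been measured, so the evidence is indirect. No step beyond the scatter is expected (a 1.0-fold lower number from compound 3 to compound 4 (0.02 log units; within the scatter)). The estimate for compound 4 is 68000 nM with an expected range (38000 nM to 120000 nM).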

Compound 4, half-maximal inhibitory concentration: > 100000 nM
Compound 4: a limit, no number; the forecaster's own chance of this, stated with the estimate: 10%; middle value at least 1.4-fold (0.16 log units) away from the limit.
By their numbers in this assay, from the lowest: compounds 1, 2 and 3 (each within the scatter of the next). At a limit, above all of these: compound 4.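

In this assay compound 4 gives (> 100000 nM), a limit of the assay and not a number. The steps (an at least 1.4-fold higher number from compound 3 to compound 4 (0.14 log units; that floor lies within the scatter)), (an at least 1.4-fold higher number from compound 2 to compound 4 (0.14 log units; that floor lies within the scatter)) and (an at least 1.6-fold higher number from compound 1 to compound 4 (0.20 log units; that floor lies within the scatter)) all have floors within the scatter, so no change beyond the scatter is established. Even so, 2-chlorophenyl on the sulfonamide nitrogen takes this series to the assay's limit for the first time among these compounds: the limit of > 100000 nM in this assay, at which 1 of the 4 values shown sits.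

Going by these compounds, how far compound 4 lies past that limit stays open. Also open, on these data alone, is how unsubstituted phenyl or pyridyl on the sulfonamide nitrogen would read, and whether an amine in place of the carboxylic acid would shift these numbers.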